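Chloro for nitro on the triazole-borne phenyl ring

The source may report more compounds than this note shows. Statements on the series, on what has been measured and on what is new or still open speak of the compounds shown alone.

Measured so far:
compound 1 `N#CC1=C(N)Oc2c(c3nc4ccccc4nc3c3ccccc23)C12C(=O)N(Cc1cnnn1-c1ccc(Cl)cc1)c1ccccc12` — in a functional assay on MCF7 cells (Homo sapiens) for antiproliferative activity, read by MTT assay, with a stated time of 48 h (a lower number here means a stronger inhibitor, a higher number a weaker inhibitor), compound 1 gives > 50000 nM, which is a limit of the assay and not a number.
compound 2 `N#CC1=C(N)Oc2c(c3nc4ccccc4nc3c3ccccc23)C12C(=O)N(Cc1cnnn1-c1ccc([N+](=O)[O-])cc1)c1ccccc12` — compound 2 gives > 50000 nM, again a limit of the assay.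
compound 3 `N#CC1=C(N)Oc2c(N)cc3nc4ccccc4nc3c2C12C(=O)N(Cc1cnnn1-c1ccc([N+](=O)[O-])cc1[N+](=O)[O-])c1ccccc12` — compound 3 gives 20900 nM, the only number in the set.

Compound 1 and compound 2 both sit at the limit of > 50000 nM in this assay, at which 2 of the 3 values shown sit. The difference between the core of compound 2 and the core of compound 3 is not broken down here. Compound 2 and compound 1 differ in one place: chloro in place of nitro on an aromatic carbon. The step that the two limits leave unreadable from compound 2 to compound 1 is therefore not readable, since both values are limits; whether the change helps, hurts or does nothing cannot be told from this pair.

Compound 4 `N#CC1=C(N)Oc2c(N)cc3nc4ccccc4nc3c2C12C(=O)N(Cc1cnnn1-c1ccc(Cl)cc1[N+](=O)[O-])c1ccccc12` has not been measured. It differs from compound 3 by chloro in place of nitro on an aromatic carbon. This is the same kind of change as from compound 2 to compound 1, not the same: in compound 4 the place is meta to a nitro group, whereas in compound 1 no such neighbour is present. Among the measured compounds shown here, no measured step fixes the size of this change, so the expectation for compound 4 rests mainly on compound 3 at 20900 nM. The step of a 1.0-fold lower number from compound 3 to compound 4 (0.02 log units; within the scatter) is expected to be small, within the usual scatter. Compound 4 is estimated at 20000 nM, with a range from 6000 nM to 60000 nM.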

Compound 4, half-maximal inhibitory concentration: > 50000 nM
Compound 4 was reported as a limit; the forecaster's own chance of this, stated with the estimate: 35%; at least 2.5-fold (0.39 log units) between middle value and limit.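

In this assay, replacing 2,4-dinitrophenyl with 4-chloro-2-nitrophenyl on the core of compound 3 gives an at least 2.3-fold higher number from compound 3 to compound 4 (0.37 log units; beyond the scatter), so on this core chloro in place of nitro weakens the antiproliferative read-out, and only a lower bound on the size of that step is known. Compound 4 gives > 50000 nM, which is a limit of the assay and not a number. The result does not show that the change carries from one core to another, as the corresponding step from compound 2 to compound 1 cannot be read and its place has no nitro group meta to it, so neither direction nor size can be compared across the two cores, and most of the series offers no number to work from: the limit of > 50000 nM in this assay, at which 3 of the 4 values shown sit.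

Still open, on these data alone, is how a fluoro, methoxy or amino group would read at the same place on the core of compound 3, and whether any of these would bring that core below the limit of the assay. Also open, as far as these compounds go, is what the nitro group retained in compound 4 adds, and whether any substituent on the phenyl ring gives a readable number on the core of compound 1.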